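Methoxy for methyl on the pyridine of compound 3

This account rests on a few compounds, and the source may have more. Where it says the series, first, only, none or still open, it means among the compounds named here.

Working notes on a small set of amide and sulfonamide oxadiazoles tested in an assay on T-REx-293 cells for inhibition of potassium channel subfamily T member 1 (Homo sapiens), read by patch clamp; on this read-out higher numbers stand for weaker inhibition and lower numbers for stronger inhibition. Compound 1 `Cc1cccc(-c2noc([C@@H](C)NC(=O)c3cc(C4CC4)nn3C)n2)c1` gives 3310 nM in this assay. Compound 2 `C[C@H](NS(=O)(=O)c1cc(C(F)(F)F)nn1C)c1nc(-c2cccc(F)c2)no1` carries a sulfonamide in place of the amide and a different aryl group; in this assay compound 2 reaches only the limit of > 30000 nM, and this limit is the one described by the limit of > 30000 nM in this assay, at which 1 of the 3 values shown sits. Compound 3 `Cc1cc(-c2noc([C@H](C)NC(=O)c3cc(C(F)(F)F)nn3C)n2)ccn1`, with the trifluoromethyl pyrazole amide and the 2-methylpyridin-4-yl group, gives 165 nM in this assay, the lowest of the two numbers obtained; the nearest number, that of compound 1, is far higher and beyond the scatter. Among the compounds with values here, no pair of measured compounds differs in only one place, so no single measured step is available.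

Compound 4 `COc1cc(-c2noc([C@H](C)NC(=O)c3cc(C(F)(F)F)nn3C)n2)ccn1` is the next compound to be measured in this assay. Its change from compound 3 is methoxy in place of methyl on an aromatic carbon. The change is small and keeps the rest of compound 3 intact, so the expected step of a 1.5-fold higher number from compound 3 to compound 4 (0.18 log units; within the scatter) is none beyond the scatter, with the number as likely to rise slightly as to fall. For compound 4 in this assay the estimate is 250 nM, expected within 80 nM to 800 nM.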

Compound 4, half-maximal inhibitory concentration: 27 nM
Estimate against measurement, compound 4: 9.3-fold (0.97 log units) above; the whole stated range lies above it.
By their numbers in this assay, from the lowest: compound 4; then compound 3; then compound 1. At a limit, above all of these: compound 2.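

In this assay, within the data shown here, going from 2-methylpyridin-4-yl to 2-methoxypyridin-4-yl gives a 6.1-fold lower number from compound 3 to compound 4 (0.79 log units; beyond the scatter), the only step so far that changes a single place. It shows that this aromatic carbon next to the ring nitrogen is not indifferent to its substituent: with the rest of the molecule held fixed, replacing the methyl with a methoxy, which brings in an oxygen, shifts the read-out beyond the scatter. Nothing measured in this set gives a reason for the direction or the size of this step.

With only methyl and methoxy shown at this position, it remains open whether the oxygen or the larger group matters, and an ethoxy, a hydroxyl, a dimethylamino group or a chlorine there would help separate the two. As far as these compounds go, it also remains open whether the methoxy for methyl change would act the same way alongside the cyclopropyl amide of compound 1 or the sulfonamide of compound 2, as both differ from compound 4 in more than one place.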